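Amide nitrogen substituent in the shared core

The source may hold more compounds than are shown below. What is called first, only, known or untested is meant among the compounds shown, and "the series" means these compounds.

Measured so far in a functional assay on CHO cells for agonist activity at Free fatty acid receptor 2 (Homo sapiens), read by cAMP accumulation; on this read-out higher numbers stand for weaker inhibition and lower numbers for stronger inhibition:
compound 1 `CNC(=O)[C@H](c1ccc(Cl)cc1)C(C)C` — 11000 nM
compound 2 `CC(C)[C@H](C(=O)Nc1ccccc1)c1ccc(Cl)cc1` — > 100000 nM

Compound 1 stands on the only number shown in this assay. Compound 2 returns a limit, not a number; it sits at the limit of > 100000 nM in this assay, at which 1 of the 2 values shown sits.

The change to compound 3 `CC(C)[C@H](C(=O)Nc1cccnn1)c1ccc(Cl)cc1` is pyridazin-3-yl in place of methyl on an amide-type nitrogen. Among the measured compounds shown here, the one measured step that bears on it replaces the same methyl with phenyl: an at least 9.0-fold higher number from compound 1 to compound 2 (0.95 log units; beyond the scatter). Compound 3 likewise carries an aromatic ring on that nitrogen, so a step of similar kind is expected, towards a higher number, beyond the scatter; whether the two ring nitrogens of the pyridazin-3-yl shift it back is not shown by any compound here.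

For compound 3 the estimate in this assay is 60000 nM (range 15000 nM to 200000 nM), a step of a 5.5-fold higher number from compound 1 to compound 3 (0.74 log units; beyond the scatter), with a real chance that only a limit is returned.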

Compound 3, half-maximal inhibitory concentration: 2300 nM
For compound 3 the middle estimate is 26-fold (1.42 log units) above the measured one; measured number outside the range, below it.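

In this assay, an aromatic ring on the amide-type nitrogen does not by itself cost activity: pyridazin-3-yl in place of methyl gives a 4.8-fold lower number from compound 1 to compound 3 (0.68 log units; beyond the scatter), opposite in direction to the step seen with phenyl. Pyridazin-3-yl in place of phenyl gives an at least 43-fold lower number from compound 2 to compound 3 (1.63 log units; beyond the scatter), so at this position the outcome depends on which ring is present, not only on a ring being present. The value of compound 2 in that step is a limit, not a number: the limit of > 100000 nM in this assay, at which 1 of the 3 values shown sits.

The compounds shown do not separate the contribution of either ring nitrogen, which a pyridin-2-yl or pyridin-3-yl group on the same nitrogen would address. From the compounds shown here alone, it also remains open how an ethyl group or a longer chain, or a saturated ring such as piperidine, would compare with methyl and pyridazin-3-yl.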